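This account rests on a few compounds, and the source may have more. Where it says the series, first, only, none or still open, it means among the compounds named here.

Compound 1 `CCCc1cc(N)c2cc(NC(=O)c3ccc(-c4ccc(Cl)cc4)cc3)ccc2n1`: 0.7 nM
Compound 2 `CCCc1cc(N)c2cc(NC(=O)/C=C/c3ccc(Cl)cc3Cl)ccc2n1`: 6.6 nM

Both compounds were tested in an assay on isolated protein for displacement of a labelled ligand from melanin-concentrating hormone receptor 1 (Homo sapiens); on this read-out higher numbers stand for weaker inhibition and lower numbers for stronger inhibition. Of the two numbers, compound 2 gives the higher one, at 6.6 nM; compound 1 gives 0.7 nM, a lower number, and the gap between them lies beyond the usual scatter. Compound 3 `CCCc1cc(N)c2cc(NC(=O)/C=C/c3ccc(N)cc3)ccc2n1` has not yet been measured. It keeps the shared core and the double-bonded chain of compound 2 but differs in one place: 4-aminophenyl in place of 2,4-dichlorophenyl on a double-bonded chain carbon bound to a double-bonded chain carbon. Among the compounds with values here, no pair of measured compounds shows a change of this kind, so the size of the step cannot be read from the numbers at hand. A step toward a higher number, meaning weaker inhibition, is expected, of moderate size and beyond the scatter. The estimate for compound 3 in this assay is 40 nM, within a range from 8 nM to 200 nM. This is expected to amount to a step of a 6.1-fold higher number from compound 2 to compound 3 (0.78 log units; beyond the scatter).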

Compound 3, half-maximal inhibitory concentration: 190 nM
The estimate for compound 3 lay 4.8-fold (0.68 log units) below the measured number, and the stated range covers the measured number.
By their numbers in this assay, from the lowest: compound 1; then compound 2; then compound 3.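

In this assay replacing 2,4-dichlorophenyl with 4-aminophenyl gives a 29-fold higher number from compound 2 to compound 3 (1.46 log units; beyond the scatter) and so weakens inhibition by a large margin. Within the data shown here, this is the first sign that the group on this double-bonded chain carbon strongly affects the result, even though both groups contain one six-membered aromatic ring of carbon only and differ little in size by heavy-atom count. Nothing measured here explains why the number rises.

The change removes two chlorines and adds an amino group in a single step, so the compounds shown cannot separate the effect of the loss from that of the gain. From the compounds shown here alone, a plain phenyl, a 4-chlorophenyl or a 4-methoxyphenyl at this place could help to tell these effects apart, and how any of them would compare remains open.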